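Two Nitrate Esters on Rat Aorta and a Third Untested

The source may hold more compounds than are shown below. What is called first, only, known or untested is meant among the compounds shown, and "the series" means these compounds.

Compound 1 `O=C(O)c1ccc([S+]([O-])CCCO[N+](=O)[O-])cc1` carries a free carboxylic acid and a nitrate-bearing side chain; in a functional assay on aorta (Rattus norvegicus, strain Wistar) for inhibition, with a stated time of 30 min (on this read-out higher numbers stand for an effect only at larger amounts of compound and lower numbers for an effect already at smaller amounts), compound 1 gives 6000 nM. Compound 2 `CC(=O)Oc1ccccc1C(=O)OCOC(=O)c1ccc([S+]([O-])CCCO[N+](=O)[O-])cc1` keeps the same side chain but has the acid masked as an ester; in this assay compound 2 gives 470 nM. Of the two numbers, that of compound 2 is the lower, and its gap to compound 1 lies beyond the usual scatter of this measurement.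

Compound 3 `CC(=O)Oc1ccccc1C(=O)OCOC(=O)c1ccc(CCCO[N+](=O)[O-])cc1` differs from compound 2 at a single spot: a group of 7 heavy atoms (3 carbon, 1 nitrogen, 3 oxygen; no ring) in place of a group of 9 heavy atoms (3 carbon, 1 nitrogen, 4 oxygen, 1 sulfur; no ring), on an aromatic carbon. Among the measured compounds shown here, no measured pair with this kind of change is available, so the expectation rests on compound 2 alone. The step of a 1.5-fold higher number from compound 2 to compound 3 (0.17 log units; within the scatter) is expected to be small, within or only just beyond the scatter, toward a somewhat higher number. Compound 3 is therefore estimated at 700 nM in this assay, with a plausible range from 200 nM to 2500 nM.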

Compound 3, half-maximal effective concentration: 75 nM
Beside the measured number, compound 3's estimate is 9.3-fold (0.97 log units) above it, and the stated range ends above it.
By their numbers in this assay, from the lowest: compound 3; then compound 2; then compound 1.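

In this assay putting 3-(nitrooxy)propyl in place of the sulfur-bearing group gives a 6.3-fold lower number from compound 2 to compound 3 (0.80 log units; beyond the scatter) and shows that what sits at this aromatic carbon clearly affects the read-out. The nitrate end stays while the sulfur and one oxygen leave, so the sulfur-bearing link is not needed for an effect at small amounts of compound on this read-out, and the number is lower without it. Nothing in the available data explains why the number falls. On these data alone, all three compounds carry the nitrate end, so whether a group without it, such as a simple propyl chain, keeps any of the effect remains open. Also open, as far as these compounds go, is how a longer chain carrying the same nitrate end, or an amine at this position, compares with 3-(nitrooxy)propyl.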